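The source may hold more compounds than are shown below. What is called first, only, known or untested is meant among the compounds shown, and "the series" means these compounds.

Measured compounds:
compound 1 `O=C(Nc1ccc(-n2cc(-c3ccncc3)c(-c3ccc(Cl)c(O)c3)n2)cc1)Nc1ccc(Cl)c(C(F)(F)F)c1` gives 1510 nM;
compound 2 `O=C(Nc1ccc(-n2cc(-c3ccncc3)c(-c3ccc(Cl)c(O)c3)n2)cc1)c1ccc(Cl)c(Cl)c1` gives 4740 nM;
compound 3 `O=C(Nc1ccc(-n2cc(-c3ccncc3)c(-c3ccc(Cl)c(O)c3)n2)cc1)c1cc(Cl)cc(Cl)c1` gives 5700 nM.

All three share one core and differ only in the group on the carbonyl carbon. In a functional assay on UACC-257 cells (Homo sapiens) for antiproliferative activity, read by sulforhodamine B assay, with a stated time of 48 h (on this read-out lower numbers stand for stronger inhibition and higher numbers for weaker inhibition), compound 3 has the highest number of the three; its nearest neighbour is compound 2, from which it is separated by a 1.2-fold higher number from compound 2 to compound 3 (0.08 log units; within the scatter), and the furthest is compound 1, separated by a 3.8-fold higher number from compound 1 to compound 3 (0.58 log units; beyond the scatter).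

Compound 4 `O=C(Nc1ccc(-n2cc(-c3ccncc3)c(-c3ccc(Cl)c(O)c3)n2)cc1)c1ccc(Cl)c(C(F)(F)F)c1` has not been measured. It differs from compound 3 in that (4-chloro-3-(trifluoromethyl)phenyl in place of 3,5-dichlorophenyl on a carbonyl carbon). The same ring is present in compound 1, but there it sits as (4-chloro-3-(trifluoromethyl)phenyl)amino on the carbonyl carbon, so the steps of a 3.1-fold higher number from compound 1 to compound 2 (0.50 log units; beyond the scatter) and a 3.8-fold higher number from compound 1 to compound 3 (0.58 log units; beyond the scatter) change two things at once and only loosely bear on this change. Going by the values given here, the one step that alters just the ring on the carbonyl carbon, a 1.2-fold higher number from compound 2 to compound 3 (0.08 log units; within the scatter), is within the scatter. On that basis a small step toward a lower number, possibly none beyond the scatter, is expected in this assay for compound 4, namely a 1.6-fold lower number from compound 3 to compound 4 (0.21 log units; within the scatter). Compound 4 is therefore estimated at 3500 nM, with a range from 1500 nM to 8000 nM.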

Compound 4, half-maximal inhibitory concentration: 2550 nM
For compound 4 the middle estimate is 1.4-fold (0.14 log units) above the measured one, and the stated range covers the measured number.
By their numbers in this assay, from the lowest: compounds 1, 4, 2 and 3 (each within the scatter of the next, the first and the last beyond it).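

In this assay, going by these compounds alone, the ring on the carbonyl carbon now shows a modest but readable effect: 4-chloro-3-(trifluoromethyl)phenyl in place of 3,5-dichlorophenyl gives a 2.2-fold lower number from compound 3 to compound 4 (0.35 log units; beyond the scatter) while the only earlier step that changed just this ring stayed within the scatter. Trifluoromethyl in place of chloro on an aromatic carbon gives a 1.9-fold lower number from compound 2 to compound 4 (0.27 log units; within the scatter) so this single swap cannot be told apart from ordinary variation between repeats. Within the data shown here, compound 4 also offers the first clean look at the amino nitrogen of compound 1, since removing that nitrogen while keeping the same ring gives a 1.7-fold higher number from compound 1 to compound 4 (0.23 log units; within the scatter) and the nitrogen alone therefore shows no effect beyond the scatter.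

On these data alone, whether a nitrile or a methoxy group in place of the trifluoromethyl, or an amine or a carboxylic acid on this ring, would move the number further remains open. Nothing available here accounts for why these rings differ.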